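Removing a Core Chloro from a Benzyl-Substituted Dichloro Scaffold

The source may report more compounds than this note shows. Statements on the series, on what has been measured and on what is new or still open speak of the compounds shown alone.

Of the compounds shown here, two have been measured so far, and they differ only in where the chloromethyl group sits on the benzyl ring. Compound 1 `ClCc1ccc(Cn2cnc3nc(Cl)nc(Cl)c32)cc1` carries it across the ring from the point of attachment, while compound 2 `ClCc1ccccc1Cn1cnc2nc(Cl)nc(Cl)c21` carries it on the position next to that attachment. In a functional assay on SF-539 cells (Homo sapiens) for cytotoxicity, read by sulforhodamine B assay, with a stated time of 48 h (on this read-out higher numbers stand for weaker inhibition of growth and lower numbers for stronger inhibition of growth), compound 1 gives 1860 nM, and in this assay compound 2 gives 2130 nM. Compound 1 has the lowest of the two numbers, but the gap to compound 2 lies within the scatter, so the two cannot be told apart on these data.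

The next compound, compound 3 `ClCc1ccc(Cn2cnc3ncnc(Cl)c32)cc1`, keeps the benzyl part of compound 1 unchanged and alters the shared core instead: hydrogen in place of chloro on an aromatic carbon. For the measured compounds named here, no measured pair shows what such a loss of a chloro does here, so there is no step to lean on. The expectation is therefore a modest weakening of growth inhibition, not clearly beyond the scatter, giving an estimated step of a 1.5-fold higher number from compound 1 to compound 3 (0.18 log units; within the scatter). Compound 3 is estimated at 2800 nM, with a plausible range from 1000 nM to 8000 nM.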

Compound 3, concentration for 50% growth inhibition: 2080 nM
Compound 3: the middle estimate sits 1.3-fold (0.13 log units) above what was measured; measured number inside the range.
By their numbers in this assay, from the lowest: compounds 1, 3 and 2 (each within the scatter of the next).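

Swapping the chloro between two ring nitrogen atoms for hydrogen gives, in this assay, a 1.1-fold higher number from compound 1 to compound 3 (0.05 log units; within the scatter), which is within the scatter, so compound 1 and compound 3 cannot be told apart. For the compounds shown here, this is the first direct look at the shared core rather than at the benzyl part, and it shows that, with this benzyl part in place, growth inhibition at this level does not depend on having a chloro on this carbon. Compound 3 keeps its other chloro group on the core, so this single change says nothing about that second chloro.

The compounds shown leave open what a larger group on this same carbon, such as an amine or a methoxy group, would do, and whether the same swap would give the same result with the benzyl part of compound 2. They also leave open what would happen if the remaining chloro group gave way to hydrogen or an amine. Nothing available here explains why this swap leaves the number within the scatter.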